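Modifying the arylidene group on the piperidine of compound 3

The source may report more compounds than this note shows. Statements on the series, on what has been measured and on what is new or still open speak of the compounds shown alone.

Of the compounds shown here, three have so far been measured in a functional assay (FL5.12 cells, Mus musculus) with Apoptosis regulator Bcl-2 (Homo sapiens) as the target; a higher number here means that more compound is needed for the effect, a lower number that less compound is needed. Compound 1 `CC1(C)CCN(c2ccc(C(=O)NS(=O)(=O)c3ccc(NC(C)(C)CSc4ccccc4)c([N+](=O)[O-])c3)cc2)CC1` gives 2200 nM in this assay, and compound 2 `COC1(Cc2ccccc2-c2ccccc2)CCN(c2ccc(C(=O)NS(=O)(=O)c3ccc(N[C@H](CCN(C)C)CSc4ccccc4)c([N+](=O)[O-])c3)cc2)CC1` gives 20 nM. Compound 3 `CN(C)CC[C@H](CSc1ccccc1)Nc1ccc(S(=O)(=O)NC(=O)c2ccc(N3CCC(=Cc4ccc(F)cc4)CC3)cc2)cc1[N+](=O)[O-]` gives 600 nM, which places it second highest of the three numbers: it lies nearest compound 1, a step that is beyond the scatter, and furthest from compound 2, whose lower number is also well beyond the scatter. No pair of these compounds differs in a single place, so no step between them can be read off directly.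

Compound 4 `CN(C)CC[C@H](CSc1ccccc1)Nc1ccc(S(=O)(=O)NC(=O)c2ccc(N3CCC(=Cc4ccccc4C(F)(F)F)CC3)cc2)cc1[N+](=O)[O-]` has not yet been measured. It differs from compound 3 in one place: 2-(trifluoromethyl)phenyl in place of 4-fluorophenyl on a double-bonded chain carbon bound to a double-bonded ring carbon. The remaining structure, including the basic side chain and the thioether, is unchanged. Among the compounds with values here, nothing among the measured compounds speaks to this particular exchange, so the direction of its effect cannot be drawn from the data. Compound 4 is therefore expected to give a value in this assay close to that of compound 3, with the step from compound 3 to compound 4 estimated as a 1.2-fold lower number from compound 3 to compound 4 (0.08 log units; within the scatter) and likely within the scatter. The estimate for compound 4 in this assay is 500 nM, with a range from 150 nM to 1800 nM.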

Compound 4, half-maximal effective concentration: 210 nM
Estimate against measurement, compound 4: 2.4-fold (0.38 log units) above; low and high end bracket the measured number.
By their numbers in this assay, from the lowest: compound 2; then compound 4; then compound 3; then compound 1.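

In this assay, within the data shown here, replacing 4-fluorophenyl with 2-(trifluoromethyl)phenyl on a double-bonded chain carbon bound to a double-bonded ring carbon gives a 2.9-fold lower number from compound 3 to compound 4 (0.46 log units; beyond the scatter), the first step in this set that can be read across a single place. It shows that this position is not silent: with the rest of the structure unchanged, the group there moves the number, and the entering group of 10 heavy atoms, against 7 for the one it replaces, does not cost activity in this pair. No measurement shown here bears on why the number falls.

The compounds shown leave open whether the step follows from the trifluoromethyl group itself or from where it stands on the aromatic ring, since the fluorine-bearing group and its place change together, and how an unsubstituted phenyl, or a nitrile or methoxy group in place of the trifluoromethyl, would read in this assay. They also leave open whether the same exchange would give a similar step if the dimethylamine of the side chain gave way to a carboxylic acid.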